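Swapping fluoro for ethyl on a cinnamamide with a weak start

The source may hold more compounds than are shown below. What is called first, only, known or untested is meant among the compounds shown, and "the series" means these compounds.

Measured so far:
compound 1, `Nc1ccccc1NC(=O)c1ccc(CSc2nccc(C(F)(F)F)n2)cc1`: 83.4%
compound 2, `Nc1ccccc1NC(=O)/C=C/c1ccc(CSc2ccc(F)cc2)cc1`: 10.4%
compound 3, `Nc1ccccc1NC(=O)c1ccc(CSc2ccc(Cl)cc2)cc1`: 51.4%

Of the compounds shown here, three have been tested in a functional assay on HeLa cells (Homo sapiens) for inhibition, read by CCK-8 assay, with a stated time of 72 h, tested at 8 uM; on this read-out lower numbers stand for less inhibition of growth and higher numbers for more inhibition of growth at the one concentration tested. Compound 1, `Nc1ccccc1NC(=O)c1ccc(CSc2nccc(C(F)(F)F)n2)cc1`, gives the highest reading, 83.4%, and compound 3, `Nc1ccccc1NC(=O)c1ccc(CSc2ccc(Cl)cc2)cc1`, gives 51.4%. Compound 2, `Nc1ccccc1NC(=O)/C=C/c1ccc(CSc2ccc(F)cc2)cc1`, stands lowest of the three with 10.4%; the gap to compound 3 and the larger gap to compound 1 both lie well beyond the usual scatter of this measurement. Compound 2 differs from the other two in more than one place at once, so none of these gaps can be tied to a single structural change.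

The new compound, compound 4, `CCc1ccc(SCc2ccc(/C=C/C(=O)Nc3ccccc3N)cc2)cc1`, keeps everything in compound 2 except one group: ethyl in place of fluoro on an aromatic carbon. For the measured compounds named here, no measured pair shows what this particular swap does in this assay, so the size of the step is open. With no guidance from the data, the expectation is that compound 4 stays near compound 2, with the step from a number 9.6 percentage points higher from compound 2 to compound 4 (within the scatter) judged small and quite possibly within the scatter. The estimate for compound 4 in this assay is therefore 20%, with a range from 5% to 45%.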

Compound 4, percent growth inhibition at one concentration: 20.9%
The estimate for compound 4 lay 0.9 percentage points below the measured number; the measured number falls inside the stated range.
By their numbers in this assay, from the lowest: compound 2; then compound 4; then compound 3; then compound 1.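

In this assay, for the compounds shown here, replacing 4-fluorophenyl with 4-ethylphenyl gives a number 10.5 percentage points higher from compound 2 to compound 4 (beyond the scatter), the first single-change comparison in this set, and it shows that the group at this place, para to a large group, can alter the reading. The step is modest, and compound 4 still reads only 20.9%, so this swap alone does not turn the weak starting compound into a strong inhibitor of growth at the one concentration tested. Neither fluoro nor ethyl carries a hydrogen-bond donor or acceptor, and no measurement available here explains why the reading rises.

As far as these compounds go, a single step cannot show a trend, so it remains open whether a longer chain such as propyl, or a different kind of group such as an amine or a carboxylic acid, would raise the reading further at this place. From the compounds shown here alone, it is also open whether ethyl would produce a similar step on compound 3, whose structure differs from compound 2 in more than one place.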